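The source may report more compounds than this note shows. Statements on the series, on what has been measured and on what is new or still open speak of the compounds shown alone.

This account follows a small series of compounds in a functional assay on the whole organism (strain Swiss) with Mus musculus as the target, in the maximal electroshock model, with a stated time of 1 h, at a dose of 300 mg/kg by the intraperitoneal route; on this read-out higher numbers stand for a stronger effect at the one dose given and lower numbers for a weaker effect. Compound 1, `CC(C(=O)N1CCN(c2ccc(Cl)cc2)CC1)N1C(=O)CCC1=O`, gives 0% in this assay. Compound 2, `CC(C(=O)N1CCN(c2ccc(C(F)(F)F)cc2)CC1)N1C(=O)CCC1=O`, gives 0%, and compound 3, `CC(C(=O)N1CCOCC1)N1C(=O)CCC1=O`, gives 0%. Compound 1 therefore stands level with compounds 2 and 3. Its nearest neighbour is compound 2, and the step of no change at the digits printed from compound 1 to compound 2 (within the scatter), which put trifluoromethyl in place of chloro on an aromatic carbon, shows no change within the scatter. Compound 3 is furthest from compound 1 in structure and carries no aromatic ring at all, yet its value and that of compound 1 are the same.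

The unmeasured compound 4, `CC(C(=O)N1CCN(c2ccccc2Cl)CC1)N1C(=O)CCC1=O`, differs from compound 1 by 2-chlorophenyl in place of 4-chlorophenyl on an amine nitrogen in a ring. Among the measured compounds shown here, no measured step moves the chlorine around the aromatic ring; the only step that touches the aromatic substituent is no change at the digits printed from compound 1 to compound 2 (within the scatter), which was flat. For the measured compounds named here, with all three measured compounds at the same level, and no step in this assay yet rising above the scatter, the step expected for compound 4 is no change at the digits printed from compound 1 to compound 4 (within the scatter), that is none beyond the scatter. Compound 4 is accordingly estimated at 0%, with a range from 0% to 25%.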

Compound 4, a percentage reported as activity, at one dose (the size of the read-out at that dose, not a potency): 25%
Beside the measured number, compound 4's estimate is 25 percentage points below it; low and high end bracket the measured number.
By their numbers in this assay, from the lowest: compounds 1, 2 and 3 (each within the scatter of the next); then compound 4.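

Moving the chlorine produces the only step so far in this assay that lies beyond the scatter, with a number 25 percentage points higher from compound 1 to compound 4 (beyond the scatter) for 2-chlorophenyl in place of 4-chlorophenyl on an amine nitrogen in a ring. The two compounds have the same atoms, joined differently, so in this pair the read-out follows where the chlorine stands on the aromatic ring; by contrast, the change of group in no change at the digits printed from compound 1 to compound 2 (within the scatter) left the number flat. No measured property is available to explain the rise, and its cause remains unknown.

The compounds shown leave open whether the rise is tied to chlorine or would also appear with 2-fluorophenyl, 2-methoxyphenyl or 2-(trifluoromethyl)phenyl on the same amine nitrogen. They also leave open how 3-chlorophenyl or plain phenyl would compare with 2-chlorophenyl and 4-chlorophenyl, so no trend around the aromatic ring can be drawn from this single pair.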